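The source may report more compounds than this note shows. Statements on the series, on what has been measured and on what is new or still open speak of the compounds shown alone.

In a toxicity assay on MT4 cells (Homo sapiens) for cytotoxicity, read by MTT assay, with a stated time of 7 days (a lower number here means that less compound is tolerated, a higher number that more compound is tolerated), compound 1 (`Cc1cc(C)cc(S(=O)(=O)c2c(C(=O)NC3CC4(CCN(C(=O)OC(C)(C)C)C4)C3)[nH]c3ccc(Cl)cc23)c1`) gives 171000 nM and compound 3 (`Cc1cc(C)cc(S(=O)(=O)c2c(C(=O)NC3CC4(CCN(C(=O)OC(C)(C)C)CC4)C3)[nH]c3ccc(Cl)cc23)c1`) gives 133000 nM, two values within the usual scatter of each other. Compound 2 (`Cc1cc(C)cc(S(=O)(=O)c2c(C(=O)NC3CC4(C3)CN(S(C)(=O)=O)C4)[nH]c3ccc(Cl)cc23)c1`) gives > 233000 nM, which is a limit of the assay and not a number. Compound 2 therefore stands at the limit of > 233000 nM in this assay, at which 1 of the 3 values shown sits.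

The next compound, compound 4 (`Cc1cc(C)cc(S(=O)(=O)c2c(C(=O)NC3CC4(CNC4)C3)[nH]c3ccc(Cl)cc23)c1`), has hydrogen in place of methylsulfonyl on an amine nitrogen in a ring. Going by the values given here, none of the measured compounds carries hydrogen at that nitrogen, and no step between measured compounds is available to size the change, so the expectation is a loose one. Compound 3, at 133000 nM, shows that a compound of this kind can give a real number in this assay. The expected change, an at least 3.8-fold lower number from compound 2 to compound 4 (0.58 log units; beyond the scatter), is downward and beyond the scatter, meaning that less compound is expected to be tolerated. For compound 4 the estimate is 60000 nM, with an expected range from 15000 nM to 200000 nM.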

Compound 4, half-maximal cytotoxic concentration: 28600 nM
Compound 4: the middle estimate sits 2.1-fold (0.32 log units) above what was measured, and the stated range covers the measured number.
By their numbers in this assay, from the lowest: compound 4; then compounds 3 and 1 (each within the scatter of the next). At a limit, above all of these: compound 2.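

In this assay, going by these compounds alone, hydrogen in place of methylsulfonyl on an amine nitrogen in a ring gives an at least 8.1-fold lower number from compound 2 to compound 4 (0.91 log units; beyond the scatter), the first step that can be read at this place, and it shows that this nitrogen's substituent can move the number beyond the scatter. With hydrogen on that nitrogen, compound 4 gives 28600 nM, a real number rather than a limit. Compound 2 gives only a limit, so the step sets a minimum and not a full size: the limit of > 233000 nM in this assay, at which 1 of the 4 values shown sits.

The compounds shown leave open how a small group such as methyl or acetyl on that nitrogen would compare with hydrogen and methylsulfonyl. On these data alone, whether the same replacement would give a similar step in the cores of compound 1 and compound 3 also remains open.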